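The compounds below may be only part of what the source reports. "The series", "measured", "known", "first", "only" and "open" are said of these compounds alone.

In an assay on the whole organism (plasma, strain Sprague-Dawley) for inhibition of Dipeptidyl peptidase 4 (Rattus norvegicus), with a stated time of 6 h, at a dose of 1 mg/kg by the oral route; on this read-out higher numbers stand for more inhibition at the one dose given (going by the name of the read-out) and lower numbers for less inhibition:

compound 1 `C=CC[C@@H]1CN[C@H](C(=O)N2CCC[C@H]2C#N)C1`: 38%
compound 2 `C[C@@H]1N[C@H](C(=O)N2CCC[C@H]2C#N)C[C@@H]1C(=O)N1CCOCC1`: 94%
compound 3 `C[C@@H]1N[C@H](C(=O)N2CCC[C@H]2C#N)C[C@@H]1C(=O)N1CCCC1`: 94%

Compound 1 gives the lowest of the three numbers in this assay; compound 2 and compound 3 each sit well beyond the scatter above it. Among the measured compounds shown here, the only one-place step measured, no change at the digits printed from compound 2 to compound 3 (within the scatter), concerns the group on the carbonyl carbon and shows that swapping one cyclic amine for another there leaves the read-out unchanged.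

Compound 4 `N#C[C@@H]1CCCN1C(=O)[C@@H]1C[C@H](C(N)=O)CN1` is not yet measured. It differs from compound 1 by carbamoyl in place of allyl on a saturated ring carbon. For the measured compounds named here, no measured step covers this exact exchange: compound 2 and compound 3 carry a carbonyl-bearing group at the same ring position but also a methyl that compound 4 lacks, so their values only hint that an amide at this carbon goes with a high read-out. A step upward is therefore expected in this assay, estimated as a number 40 percentage points higher from compound 1 to compound 4 (beyond the scatter), with real uncertainty about its size. For compound 4 the expected value is 78%, within 55% to 95%.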

Compound 4, a percentage reported as inhibition, in the whole organism at one dose (the size of the read-out at that dose, not a potency): 47%
Compound 4: the middle estimate sits 31 percentage points above what was measured; measured number below the stated range.
By their numbers in this assay, from the lowest: compounds 1 and 4 (each within the scatter of the next); then compounds 2 and 3 (each within the scatter of the next).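

Carbamoyl in place of allyl on this saturated ring carbon reads in this assay as a number 9 percentage points higher from compound 1 to compound 4 (within the scatter) and gives the first direct view of an exchange at this position. At the one dose given, the two groups cannot be told apart, so a carbamoyl group on this carbon does not by itself set compound 4 apart from compound 1. Nothing at hand gives a reason for this result.

Compound 2 and compound 3 differ from compound 4 in more than one place, so the shares of their methyl and of their ring amides in the numbers they give remain unresolved. Also open, on these data alone, is how a carboxylic acid, an aminomethyl group or a longer chain on this carbon would read in this assay.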